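The compounds below may be only part of what the source reports. "The series", "measured", "known", "first", "only" and "open" are said of these compounds alone.

Of the compounds shown here, three that share one core have been tested so far. In a functional assay on NCI-H460 cells (Homo sapiens) for cytotoxicity, read by MTT assay, with a stated time of 68 h (on this read-out higher numbers stand for weaker inhibition and lower numbers for stronger inhibition), compound 1 (`Cc1ccccc1-c1cccc(NC(=O)C(Cl)Cl)c1`) gives 31600 nM, compound 2 (`O=C(Nc1cccc(-c2ccccc2F)c1)C(Cl)Cl`) gives 26800 nM and compound 3 (`O=C(Nc1cccc(-c2ccccc2)c1)C(Cl)Cl`) gives 20200 nM. Compound 3 therefore stands level with the other two, since its gaps to both lie within the scatter of repeated measurements.

The next compound is compound 4 (`O=C(Nc1cccc(-c2ccccc2Cl)c1)C(Cl)Cl`). It is made from compound 3 by one change: chloro in place of hydrogen on an aromatic carbon. In words, chloro takes the place of hydrogen on an aromatic carbon, ortho to a large group. Among the compounds with values here, no tested compound carries a chloro, so the closest guide comes from the two compounds with another group on an aromatic carbon of that ring. Removing methyl gives a 1.6-fold lower number from compound 1 to compound 3 (0.19 log units; within the scatter), and removing fluoro gives a 1.3-fold lower number from compound 2 to compound 3 (0.12 log units; within the scatter). The exchange of fluoro for methyl gives a 1.2-fold lower number from compound 1 to compound 2 (0.07 log units; within the scatter). All three steps are small and within the scatter, so no step beyond the scatter is expected in this assay for this change, though the tested compounds hint weakly at a slightly higher number.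

For compound 4 the estimated value is 25000 nM, with an expected range from 13000 nM to 45000 nM. This estimate means an expected 1.2-fold higher number from compound 3 to compound 4 (0.09 log units; within the scatter).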

Compound 4, half-maximal inhibitory concentration: > 50000 nM
Compound 4 was reported as a limit; the forecaster's own chance of this, stated with the estimate: 5%; at least 2.0-fold (0.30 log units) between middle value and limit.
By their numbers in this assay, from the lowest: compounds 3, 2 and 1 (each within the scatter of the next). At a limit, above all of these: compound 4.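

Chloro in place of hydrogen on this aromatic carbon, ortho to a large group, gives an at least 2.4-fold higher number from compound 3 to compound 4 (0.39 log units; beyond the scatter), meaning weaker inhibition and the first step in this set that clearly exceeds the scatter, whereas methyl, fluoro and hydrogen at this position could not be told apart. The comparisons with the other two groups are less firm: chloro in place of fluoro gives an at least 1.8-fold higher number from compound 2 to compound 4 (0.27 log units; that floor lies within the scatter), and chloro in place of methyl gives an at least 1.5-fold higher number from compound 1 to compound 4 (0.19 log units; that floor lies within the scatter), so on these floors alone chloro is not yet separated from fluoro or methyl, although the true gaps may be larger. Compound 4 is reported in this assay as a limit and not as a number: the limit of > 50000 nM in this assay, at which 1 of the 4 values shown sits.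

The compounds shown leave open how far the true value of compound 4 lies past that limit, and so the full size of all three steps. They also leave open whether the loss is particular to chloro or would also appear with bromo, methoxy or an amine on the same aromatic carbon.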